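Replacing a formyl end with an ethoxycarbonyl end

The source may hold more compounds than are shown below. What is called first, only, known or untested is meant among the compounds shown, and "the series" means these compounds.

Measured so far in a functional assay on thoracic aorta (Rattus norvegicus, strain Sprague-Dawley); a lower number here means that less compound is needed, a higher number that more compound is needed for the effect
Compound 1 `Cc1nc(C)c(COc2ccc(COc3ccc(C=O)cc3)cc2)nc1C` gives 751000 nM
Compound 2 `Cc1nc(C)c(COc2ccc(COC(=O)c3cccnc3)cc2)nc1C` gives 379000 nM

Among the compounds with values here, compound 1 has no clear place of its own on these numbers, since its only neighbour lies within the usual scatter. Compound 3 `CCOC(=O)c1ccc(OCc2ccc(OCc3nc(C)c(C)nc3C)cc2)cc1` keeps the core of compound 1 and differs by ethoxy in place of hydrogen on a carbonyl carbon, which turns formyl into ethoxycarbonyl. Within the data shown here, the only measured step, a 2.0-fold lower number from compound 1 to compound 2 (0.30 log units; within the scatter), swapped out the whole 4-formylphenyl group, so it bears on this change only loosely and gives no sign of a large shift in this assay. The expected step stays within the scatter, namely a 1.5-fold lower number from compound 1 to compound 3 (0.18 log units; within the scatter). For compound 3 the estimate is 500000 nM, with an expected range from 170000 nM to 1500000 nM.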

Compound 3, half-maximal effective concentration: 751000 nM
For compound 3 the middle estimate is 1.5-fold (0.18 log units) below the measured one; the measured number falls inside the stated range.
By their numbers in this assay, from the lowest: compounds 2, 1 and 3 (each within the scatter of the next).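

In this assay, within the data shown here, this is the first change confined to the end group with the rest of the molecule held fixed, and ethoxy in place of hydrogen on the carbonyl carbon gives no change at the digits printed from compound 1 to compound 3 (within the scatter). At this place, then, formyl and ethoxycarbonyl cannot be told apart by this read-out, even though the entering group brings an extra oxygen and a two-carbon chain. Nothing measured here offers a reason for this result.

As far as these compounds go, it remains open whether a carboxylic acid or an amine-derived amide on this carbonyl carbon would read differently. A longer chain in place of ethoxy is equally unsettled.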